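Swapping Butyl for Isobutoxy on the Carbonyl

A few compounds are considered here, and "the series" means these few. Any claim that something is new, unique, unknown or untested is made for them only; others in the source may bear on it.

Of the compounds shown here, two built on one shared core have been measured in a functional assay on BeWo cells (Homo sapiens) for inhibition, read by MTT assay, with a stated time of 72 h; on this read-out higher numbers stand for weaker inhibition and lower numbers for stronger inhibition. Compound 1 `CCCCC(=O)N1CCN(c2nnc3nncn3n2)CC1` stands lowest of the two: in this assay compound 1 gives 1720 nM. Compound 2 `c1nnc2nnc(NC3CCCC3)nn12`, which carries a different side group on the same core, gives 34700 nM in this assay, a markedly higher number that lies well beyond the usual scatter of repeated measurements, so compound 1 is clearly the stronger inhibitor of the pair.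

Compound 3 `CC(C)COC(=O)N1CCN(c2nnc3nncn3n2)CC1` has not yet been measured. It differs from compound 1 in a single place: isobutoxy in place of butyl on a carbonyl carbon. The group that leaves and the group that enters are close in size, and nothing else in the molecule changes.

Among the measured compounds shown here, no two measured compounds differ in just one place, so there is no comparable step to lean on. The step of a 1.5-fold higher number from compound 1 to compound 3 (0.16 log units; within the scatter) is expected to be small, toward a slightly higher number, and probably within the scatter. Compound 3 is therefore expected to give about 2500 nM in this assay, with a range from 800 nM to 8000 nM.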

Compound 3, half-maximal inhibitory concentration: 13100 nM
Beside the measured number, compound 3's estimate is 5.2-fold (0.72 log units) below it; the measured number lies above the stated range.
By their numbers in this assay, from the lowest: compound 1; then compound 3; then compound 2.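

In this assay, replacing butyl with isobutoxy on the carbonyl carbon gives a 7.6-fold higher number from compound 1 to compound 3 (0.88 log units; beyond the scatter), a step beyond the usual scatter, so inhibition in this series responds clearly to what sits at this position, even when the two groups are close in size and both hold four carbons. The swap changes two things at once: an oxygen now joins the chain to the carbonyl carbon, turning butylcarbonyl into isobutoxycarbonyl, and the straight chain gives way to a branched one. Nothing measured here explains why inhibition weakens with this change.

On these data alone, whether the weaker inhibition follows the oxygen, the branch or both stays open, since this single step changes them together. A butoxy group on the same carbonyl would carry the oxygen without the branch and an isopentyl group would carry the branch without the oxygen, so that pair of groups could tell the two changes apart.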